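This account rests on a few compounds, and the source may have more. Where it says the series, first, only, none or still open, it means among the compounds named here.

Among the three compounds measured in a functional assay on cells (T-cell, Homo sapiens) for inhibition (a higher number here means a weaker inhibitor, a lower number a stronger inhibitor), compound 3 `COc1ccc(-c2cnc3nc(N)nc(N4CCN(C(=O)Nc5cccc(C)c5)CC4)c3n2)cc1OC` gives 7 nM and stands second highest of the three numbers. Its nearest neighbour is compound 1 `COc1ccc(-c2cnc3nc(N)nc(N4CCN(C(=O)COc5ccccc5)CC4)c3n2)cc1OC`, which gives 4 nM; the step of a 1.8-fold higher number from compound 1 to compound 3 (0.24 log units; within the scatter) lies within the scatter. Its furthest neighbour is compound 2 `COc1ccc(-c2cnc3nc(N)nc(N4CCN(C(=O)c5ccccc5)CC4)c3n2)cc1OC`, which gives 400 nM; the step of a 57-fold lower number from compound 2 to compound 3 (1.76 log units; beyond the scatter) is large. The change to compound 4 `COc1ccc(-c2cnc3nc(N)nc(N4CCN(C(=O)Nc5ccc(C#N)cc5)CC4)c3n2)cc1OC` is 4-cyanophenyl in place of 3-methylphenyl on an amide-type nitrogen. For the measured compounds named here, none of the measured steps alters the ring on the (3-methylphenyl)carbamoyl group; all of them, a 100-fold higher number from compound 1 to compound 2 (2.00 log units; beyond the scatter), a 1.8-fold higher number from compound 1 to compound 3 (0.24 log units; within the scatter) and a 57-fold lower number from compound 2 to compound 3 (1.76 log units; beyond the scatter), exchange the whole group on the carbonyl carbon, so no step bears directly on this change. The (3-methylphenyl)carbamoyl of compound 3 already sits close to compound 1 in this assay, so the estimate for compound 4 is a step of a 1.4-fold higher number from compound 3 to compound 4 (0.15 log units; within the scatter) that stays within the scatter. Compound 4 is therefore expected at about 10 nM, within a range of 3 nM to 40 nM.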

Compound 4, half-maximal inhibitory concentration: 74 nM
The estimate for compound 4 lay 7.4-fold (0.87 log units) below the measured number, and the stated range ends below it.
By their numbers in this assay, from the lowest: compounds 1 and 3 (each within the scatter of the next); then compound 4; then compound 2.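

In this assay, an 11-fold higher number from compound 3 to compound 4 (1.02 log units; beyond the scatter) shows that the ring on the amide-type nitrogen matters in its own right: with the carbonyl and that nitrogen kept, exchanging 3-methylphenyl for 4-cyanophenyl moves the number beyond the scatter, which the earlier whole-group exchanges could not show. A (phenyl-type)amino group on the carbonyl carbon therefore does not by itself keep the number close to that of compound 1, as a 19-fold higher number from compound 1 to compound 4 (1.27 log units; beyond the scatter) is large, while a 5.4-fold lower number from compound 2 to compound 4 (0.73 log units; beyond the scatter) is only modest. Nothing available accounts for this shift.

The substituent and its place on the ring change together, so the compounds shown do not separate the two. Going by these compounds, whether 4-methylphenyl, 3-cyanophenyl or unsubstituted phenyl on that nitrogen would sit nearer compound 3 or compound 4 remains open.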